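Two Methyl Groups on a Compound Already at the Limit

A few compounds are considered here, and "the series" means these few. Any claim that something is new, unique, unknown or untested is made for them only; others in the source may bear on it.

In an ADME assay on BJ cells (Homo sapiens) for cytotoxicity, read by luminescence, with a stated time of 72 h (a lower number here means that less compound is needed, a higher number that more compound is needed for the effect), compound 1 `CCOC(=O)c1c(-c2cccc(-c3ccccc3)c2)[nH]c2cc(OC)ccc2c1=O` gives > 21500 nM as a limit of the assay and not a number. Compound 2 `CCOC(=O)c1c(-c2cccc(-c3ccccc3)c2)[nH]c2cc(OC)c(F)cc2c1=O` gives > 21500 nM as a limit too, so its standing is known only through that limit. For the measured compounds named here, the one measured step is a step that the two limits leave unreadable from compound 1 to compound 2 for fluoro in place of hydrogen on an aromatic carbon, which leaves no size to carry forward. Going by the values given here, for compound 1 and compound 2 the only guide is the limit of > 21500 nM in this assay, at which 2 of the 2 values shown sit, and no true number lies behind it.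

Compound 3 `CCOC(=O)c1c(-c2cccc(-c3c(C)cccc3C)c2)[nH]c2cc(OC)c(F)cc2c1=O` has 2,6-dimethylphenyl in place of phenyl on an aromatic carbon, meta to a large group, and 2,6-dimethylphenyl in place of phenyl on an aromatic carbon sets out this difference from compound 2 in full.

With compound 2 at > 21500 nM as a limit, no step beyond the usual scatter is expected in this assay in either direction. The expected size is a step that the limit leaves unreadable from compound 2 to compound 3 in this estimate. For compound 3 the estimated value is 22000 nM with an expected range from 9000 nM to 45000 nM and another limit as the likeliest report.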

Compound 3, half-maximal effective concentration: > 21500 nM
Compound 3 ended at the assay's limit; the forecaster's own chance of this, stated with the estimate: 75%; the middle value does not contradict the limit.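

Compound 2 and compound 3 give no step that can be read, so the change from phenyl to 2,6-dimethylphenyl has no size here, as both rest on a limit and not on a number: the limit of > 21500 nM in this assay, at which 3 of the 3 values shown sit.

The compounds shown leave open how much of any of them this assay would need for the effect, and whether either change alters that amount.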